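Swapping the benzyl group on a weak inhibitor

This account rests on a few compounds, and the source may have more. Where it says the series, first, only, none or still open, it means among the compounds named here.

In a functional assay on BT-474 cells (Homo sapiens) for inhibition, read by MTT assay, with a stated time of 5 days (a higher number here means a weaker inhibitor, a lower number a stronger inhibitor), compound 3 `Cc1cc(Nc2nc(NCc3ccc(Cl)cc3)nc3c2cnn3CC(C)(C)O)n[nH]1` gives 16200 nM, level with compound 2 `Cc1cc(Nc2nc(NCc3ccc(Cl)cc3)nc3c2cnn3C2CCOCC2)n[nH]1` at 18300 nM. Compound 4 `Cc1cc(Nc2nc(NCc3ccc(F)cc3F)nc3c2cnn3CC(C)(C)O)n[nH]1` has 2,4-difluorophenyl in place of 4-chlorophenyl on a saturated chain carbon bound to a nitrogen on an aromatic ring. Among the measured compounds shown here, the one measured step, a 1.1-fold lower number from compound 2 to compound 3 (0.05 log units; within the scatter), concerns another group, so it cannot size this change. Compound 1 `Cc1cc(Nc2nc(NCc3ccc(F)cc3F)nc3[nH]ncc23)n[nH]1` carries the same 2,4-difluorobenzyl group and gives a lower 3220 nM, but it also differs from compound 3 on the aromatic nitrogen, so it offers only a hint. A modest fall is therefore expected, an estimated 2.2-fold lower number from compound 3 to compound 4 (0.33 log units; beyond the scatter). For compound 4 the expected value is 7500 nM, with an estimated range of 2800 nM to 18000 nM.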

Compound 4, half-maximal inhibitory concentration: 19400 nM
Beside the measured number, compound 4's estimate is 2.6-fold (0.41 log units) below it; measured number above the stated range.
By their numbers in this assay, from the lowest: compound 1; then compounds 3, 2 and 4 (each within the scatter of the next).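

Exchanging 4-chlorophenyl for 2,4-difluorophenyl at this position makes no difference that can be told from scatter, with a 1.2-fold higher number from compound 3 to compound 4 (0.08 log units; within the scatter) as the step. The group on the aromatic nitrogen now has a comparison free of other changes: 2-hydroxy-2-methylpropyl in place of hydrogen gives a 6.0-fold higher number from compound 1 to compound 4 (0.78 log units; beyond the scatter), so this gap follows the nitrogen group, not the benzyl group. Nothing measured here explains either result. Still open, as far as these compounds go, is how a methyl group or an amine-bearing chain on that nitrogen would read, and whether the 4-chlorobenzyl group behaves alike with hydrogen there.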